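The source may report more compounds than this note shows. Statements on the series, on what has been measured and on what is new or still open speak of the compounds shown alone.

Compound 1 `COc1ccc(N(CC(=O)NCCC[Se]c2ccccc2)C(=O)c2ccccc2)cc1` is the starting point of this step. In a functional assay on A-431 cells (Homo sapiens) for cytotoxicity, read by MTT assay, with a stated time of 24 h (on this read-out lower numbers stand for stronger inhibition and higher numbers for weaker inhibition), compound 1 gives >= 100000 nM, which is a limit of the assay and not a number. Compound 1 thus stands at the limit of >= 100000 nM in this assay, at which 2 of the 3 values shown sit. Compound 2 `COc1ccc(N(CC(=O)NCCCSc2ccccc2)C(=O)/C=C/c2ccccc2)cc1` is a relative of compound 1. In this assay compound 2 gives >= 100000 nM, again a limit rather than a number. Compound 3 `COc1ccc(N(CC(=O)NCCC[Te]c2ccccc2)C(=O)CCSC2=C(C)C(=O)c3ccccc3C2=O)cc1` is the only one of the three measured compounds to yield a number, reaching 1000 nM in this assay.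

Compound 4 `COc1ccc(N(CC(=O)NCCC[Se]c2ccccc2)C(=O)C#Cc2ccccc2)cc1` has not yet been measured. It differs from compound 1 by 2-phenylethynyl in place of phenyl on a carbonyl carbon whose other neighbour is an amide-type nitrogen. Among the measured compounds shown here, no measured pair of compounds shows what this change alone does. With compound 1 sitting at the limit, the step expected is a number no higher from compound 1 to compound 4 (the limit leaves the size open), no change beyond the usual scatter. Compound 4 is expected to give 100000 nM in this assay, within a range from 30000 nM to 300000 nM, and most probably only a limit would again be reported.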

Compound 4, half-maximal inhibitory concentration: >= 100000 nM
Compound 4: no number, only a limit (the forecaster's own chance of this, stated with the estimate: 75%); the middle value lies on the limit itself.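

Compound 4, like compound 1, gives only a limit and not a number, so no step can be read between compound 1 and compound 4: the limit of >= 100000 nM in this assay, at which 3 of the 4 values shown sit.

Going by these compounds, whether 2-phenylethynyl in place of phenyl on a carbonyl carbon changes the result in this assay at all stays open.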